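Compound 3 to compound 4: methyl on the amide nitrogen

The source may report more compounds than this note shows. Statements on the series, on what has been measured and on what is new or still open speak of the compounds shown alone.

Values so far in a functional assay on KETR3 cells (Homo sapiens) for inhibition, read by MTT assay, with a stated time of 120 h (a higher number here means a weaker inhibitor, a lower number a stronger inhibitor), are:
compound 1 `C/C(=C\c1ccc(NC(=O)Nc2ccc(Cl)c(C(F)(F)F)c2)cc1)C(=O)NC(C)c1ccccc1` gives > 50000 nM as a limit
compound 2 `CNC(=O)/C(C)=C/c1ccc(NC(=O)Nc2ccc(Cl)c(C(F)(F)F)c2)cc1` gives > 50000 nM as a limit
compound 3 `CC(NC(=O)CCc1ccc(NC(=O)Nc2ccc(Cl)c(C(F)(F)F)c2)cc1)c1ccccc1` gives > 50000 nM as a limit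

Compound 3 has no number, only the limit > 50000 nM in this assay for now. The whole set stands at the limit of > 50000 nM in this assay, at which 3 of the 3 values shown sit, with no exception so far. Compound 4 `CNC(=O)CCc1ccc(NC(=O)Nc2ccc(Cl)c(C(F)(F)F)c2)cc1` carries methyl in place of 1-phenylethyl on an amide-type nitrogen. For the measured compounds named here, the one measured step with this exchange is a step that the two limits leave unreadable from compound 1 to compound 2 and gives no size to carry over. No step beyond the scatter is therefore expected in this assay and another limit is the likeliest reading. The estimated step is a number no higher from compound 3 to compound 4 (the limit leaves the size open) and is expected to stay within the scatter. Compound 4 is expected at 50000 nM with an estimated range from 25000 nM to 100000 nM in this series.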

Compound 4, half-maximal inhibitory concentration: 24000 nM
Compound 4: the middle estimate sits 2.1-fold (0.32 log units) above what was measured; the whole stated range lies above it.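

In this assay, the exchange of 1-phenylethyl for methyl on the amide-type nitrogen now has a readable size, an at least 2.0-fold lower number from compound 3 to compound 4 (0.31 log units; beyond the scatter), whereas the same exchange between the two earlier limits could not be read. The chain also matters once methyl is in place, with 2-(methylcarbamoyl)ethyl in place of 2-(methylcarbamoyl)prop-1-en-1-yl on the aromatic carbon giving an at least 2.0-fold lower number from compound 2 to compound 4 (0.31 log units; beyond the scatter). Most of the set still stands at a limit: the limit of > 50000 nM in this assay, at which 3 of the 4 values shown sit.

Open, going by these compounds, is whether an amine, a carboxylic acid or a longer chain on the amide-type nitrogen would lower the number further.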